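Shortening the Side Chain of Compound 3

The source may hold more compounds than are shown below. What is called first, only, known or untested is meant among the compounds shown, and "the series" means these compounds.

In a functional assay on NCI-H460 cells (Homo sapiens) for inhibition, read by MTT assay, with a stated time of 72 h (on this read-out higher numbers stand for weaker inhibition and lower numbers for stronger inhibition), compound 3 `COc1cc(NC(C)CCCNC(=O)NNC(=O)Nc2ccc(Cl)cc2)c2ncccc2c1` gives 63000 nM, the higher of the two exact numbers in this small set. Compound 1 `COc1cc(NC(C)CCCNC(=O)Nc2cccc(F)c2)c2ncccc2c1` gives 24000 nM, and the step between them is a 2.6-fold higher number from compound 1 to compound 3 (0.42 log units; beyond the scatter). Compound 2 `COc1cc(NC(C)CCCNC(=O)NNC(=O)Nc2ccc(F)cc2)c2ncccc2c1` reads > 100000 nM, which is a limit of the assay and not a number.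

The next comparison is with compound 4 `COc1cc(NC(C)CCCNC(=O)Nc2ccc(F)cc2)c2ncccc2c1`. The structural change is 4-fluorophenyl in place of ((4-chlorophenyl)carbamoyl)amino on an amide-type nitrogen.

Two measured steps run the opposite way, each bringing in a carbamoylamino group of this kind. One is an at least 4.1-fold higher number from compound 1 to compound 2 (0.61 log units; beyond the scatter), and the other is a 2.6-fold higher number from compound 1 to compound 3 (0.42 log units; beyond the scatter). Both lie beyond the scatter, and both go towards a higher number, although they start from 3-fluorophenyl rather than 4-fluorophenyl. The halogen swap gives a less firm guide, since the floor of an at least 1.5-fold lower number from compound 2 to compound 3 (0.20 log units; that floor lies within the scatter) lies within the scatter.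

Removing the group is therefore expected to give a modest move towards a lower number in this assay, and thus stronger inhibition. The expected change is a 2.4-fold lower number from compound 3 to compound 4 (0.38 log units; beyond the scatter). For compound 4, the estimated value is 26000 nM, with an expected range of 10000 nM to 60000 nM.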

Compound 4, half-maximal inhibitory concentration: 26000 nM
For compound 4 middle estimate and measured number coincide at the digits printed; the measured number falls inside the stated range.
By their numbers in this assay, from the lowest: compounds 1 and 4 (each within the scatter of the next); then compound 3. At a limit, above all of these: compound 2.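

In this assay, for the compounds shown here, taking out the ((4-chlorophenyl)carbamoyl)amino group and setting 4-fluorophenyl on the amide-type nitrogen gives a 2.4-fold lower number from compound 3 to compound 4 (0.38 log units; beyond the scatter), the first step in this set that removes such a group rather than bringing one in. The sharper comparison is an at least 3.8-fold lower number from compound 2 to compound 4 (0.58 log units; beyond the scatter), since the fluorine-bearing ring stays the same and only the carbamoylamino unit goes, but this step gives only a floor, because compound 2 stands at a limit: the limit of > 100000 nM in this assay, at which 1 of the 4 values shown sits. Going by these compounds alone, with a 1.1-fold higher number from compound 1 to compound 4 (0.03 log units; within the scatter), the swap of 3-fluorophenyl for 4-fluorophenyl shows no readable change, so the higher numbers in the earlier steps from compound 1 go with the added carbamoylamino unit and not with the different fluorine position, and none of the four compounds goes against this.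

The compounds shown leave open whether 4-chlorophenyl set directly on the amide-type nitrogen would read like compound 4, so the chloro and fluoro comparison rests on the longer compounds alone. They also leave open how a shorter or longer chain between the core and the carbonyl, or an amine or carboxylic acid in place of the halogen, would read in this assay.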